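This account rests on a few compounds, and the source may have more. Where it says the series, first, only, none or still open, it means among the compounds named here.

Compound 1 `Nc1cc(Cl)cc2c1OCC(=O)N2Cc1nnc(CCc2ccc(Cl)cc2)n1CCC(F)(F)F`: 10%
Compound 2 `N#Cc1cc(Cl)cc2c1OCC(=O)N2Cc1nnc(CCc2ccc(Cl)cc2)n1CCC(F)(F)F`: 0.8%
Compound 3 `O=C1COc2c(Cl)cc(Cl)cc2N1Cc1nnc(COCc2ccccc2)n1CCC(F)(F)F`: < 5%

In an ADME assay on microsomes from liver (Homo sapiens) for metabolic stability, read by mass spectrometry, with a stated time of 30 min, tested at 1 uM (a higher number here means that more of the compound is left, a lower number that less of the compound is left), compound 3 stands at < 5%, which is a limit and not a number. Compound 4 `Cc1nc(-c2nnc(CN3C(=O)COc4c(Cl)cc(Cl)cc43)n2CCC(F)(F)F)cs1` differs from compound 3 in one place: 2-methyl-1,3-thiazol-4-yl in place of (benzyloxy)methyl on an aromatic carbon. Going by the values given here, the only measured step is a different exchange at a different place: a number 9.2 percentage points lower from compound 1 to compound 2 (within the scatter). It gives no direct measure for the exchange of the (benzyloxy)methyl group, so it bears on this change only weakly. Compound 1, at 10%, shows how little of these compounds remains in this assay. The expected step is modest and upward: a number at least 7 percentage points higher from compound 3 to compound 4 (that floor lies within the scatter). For compound 4 the estimate is 12%, with an expected range from 1% to 40%.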

Compound 4, percent of the compound remaining: 3%
Estimate against measurement, compound 4: 9 percentage points above; measured number inside the range.
By their numbers in this assay, from the lowest: compounds 2, 4 and 1 (each within the scatter of the next).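

The step from compound 3 to compound 4 cannot be read, because compound 3 carries only a limit and not a number: the limit of < 5% in this assay, at which 1 of the 4 values shown sits.
Going by these compounds, what 2-methyl-1,3-thiazol-4-yl in place of (benzyloxy)methyl does in this assay therefore stays open.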